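The source may hold more compounds than are shown below. What is called first, only, known or untested is meant among the compounds shown, and "the series" means these compounds.

Of the compounds shown here, two of the same core have been measured so far. Compound 1 `CN(CCC1CCNCC1)C(=O)c1ccc2c(c1)CC(CC(=O)O)C(=O)N(C1CCCCC1)C2` carries a cyclohexyl on an amide-type nitrogen in a ring, and in a functional assay (plasma) for inhibition, with Homo sapiens as the target (a higher number here means a weaker inhibitor, a lower number a stronger inhibitor), compound 1 gives 49 nM. Compound 2 `CN(CCC1CCNCC1)C(=O)c1ccc2c(c1)CC(CC(=O)O)C(=O)N(Cc1ccccc1)C2` carries a benzyl there instead, and in this assay compound 2 gives 36 nM. Of these two numbers, that of compound 1 is the higher, yet the gap between them, a 1.4-fold lower number from compound 1 to compound 2 (0.13 log units; within the scatter), stays within the scatter, so the two groups cannot be told apart on this evidence.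

Compound 3 `CN(CCC1CCNCC1)C(=O)c1ccc2c(c1)CC(CC(=O)O)C(=O)N(C)C2` differs from compound 1 in this way: methyl in place of cyclohexyl on an amide-type nitrogen in a ring. Among the compounds with values here, the only measured step that bears on the change is the one from compound 1 to compound 2, and it was flat. That step, however, exchanged one ring-bearing group for another, whereas here a single carbon takes the place of a six-membered ring. Within the data shown here, no measured step tests so large a cut in size, so the expectation rests on compound 1 alone and is uncertain. Compound 3 is expected to be a somewhat weaker inhibitor, with the step from compound 1 to compound 3 estimated at a 3.1-fold higher number from compound 1 to compound 3 (0.49 log units; beyond the scatter). The estimate for compound 3 in this assay is 150 nM, within a range from 45 nM to 500 nM.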

Compound 3, half-maximal inhibitory concentration: 33 nM
Compound 3: middle estimate off by 4.5-fold (0.66 log units), on the high side, outside the stated range (below it).
By their numbers in this assay, from the lowest: compounds 3, 2 and 1 (each within the scatter of the next).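

The group on this amide-type nitrogen in a ring can shrink far more than the earlier pair tested: in this assay, going from cyclohexyl, with 6 heavy atoms and a ring, to methyl, with 1 heavy atom and no ring, gives a 1.5-fold lower number from compound 1 to compound 3 (0.17 log units; within the scatter) and stays within the scatter, while hydrogen in place of the phenyl of the benzyl gives a 1.1-fold lower number from compound 2 to compound 3 (0.04 log units; within the scatter) and also stays within it. Compounds 1, 2 and 3 therefore cannot be told apart in this assay, which means that among these three, neither a ring nor the larger size of the group at this position is needed for a value of this order. Nothing measured alongside these values offers an explanation for this flat result.

Still open, on these data alone, is what happens with a bare hydrogen on this nitrogen, or with an amine or a carboxylic acid at the end of a longer chain there. As far as these compounds go, it is also open whether a group much larger than benzyl, such as a biphenylmethyl, would keep the value in the same range.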